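This account rests on a few compounds, and the source may have more. Where it says the series, first, only, none or still open, it means among the compounds named here.

Measured so far:
Compound 1 `Fc1cccc(Cn2ccc3nc(-c4ccccc4)nc-3c2)c1`: > 100000 nM (a limit of the assay)
Compound 2 `Clc1ccc(Cn2ccc3nc(-c4ccccc4)nc-3c2)cc1Cl`: 71000 nM

Among the measured compounds shown here, in an ADME assay on MDBK cells (Bos taurus) for cytotoxicity (on this read-out lower numbers stand for higher toxicity in this test and higher numbers for lower toxicity in this test), compound 2 gives 71000 nM, the only true number available so far. Compound 1 gives > 100000 nM, which is a limit of the assay and not a number.

The next compound, compound 3 `CCn1ccc2nc(-c3ccccc3)nc-2c1`, shares the core of compound 2 but carries methyl in place of 3,4-dichlorophenyl on a saturated chain carbon bound to an aromatic nitrogen.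

For the measured compounds named here, one measured step bears on this change: an at least 1.4-fold lower number from compound 1 to compound 2 (0.14 log units; that floor lies within the scatter). It swaps one substituted phenyl for another at the same place, and as a floor within the scatter it fixes no size. A small move toward higher numbers in this assay is therefore expected, possibly none beyond the scatter. The expected change is a 1.4-fold higher number from compound 2 to compound 3 (0.15 log units; within the scatter). For compound 3 the estimated value is 100000 nM, with an expected range from 45000 nM to 220000 nM, and the assay may well report only a limit.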

Compound 3, half-maximal cytotoxic concentration: > 100000 nM
Compound 3 ended at the assay's limit; the forecaster's own chance of this, stated with the estimate: 60%; the middle value lies on the limit itself.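

In this assay, methyl in place of 3,4-dichlorophenyl on a saturated chain carbon bound to an aromatic nitrogen gives an at least 1.4-fold higher number from compound 2 to compound 3 (0.14 log units; that floor lies within the scatter). Compound 3 gives > 100000 nM, which is a limit of the assay. This position therefore now holds a group with no ring as well as two substituted phenyls, and in none of the three compounds does the read-out show a step beyond the scatter, while the step from compound 1 to compound 3 cannot be read at all because both ends sit at the same limit: the limit of > 100000 nM in this assay, at which 2 of the 3 values shown sit.

Going by these compounds, the true size of the step to compound 3 stays open, and so does the question of whether any group at this place can give a number clearly separated from that of compound 2. Also open, on these data alone, is what a longer chain, an amine or a carboxylic acid on this saturated chain carbon would give in this assay.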